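A few compounds are considered here, and "the series" means these few. Any claim that something is new, unique, unknown or untested is made for them only; others in the source may bear on it.

Of the compounds shown here, three that share one core have been measured in a functional assay on PC-3 cells (Homo sapiens) for inhibition; on this read-out lower numbers stand for stronger inhibition and higher numbers for weaker inhibition. Compound 1 `Cc1c(C(=O)N/N=C\c2ccccc2C(F)(F)F)oc2cccc(O)c12` gives 26200 nM in this assay, which places it at the weak end of inhibition. Compound 3 `Cc1c(C(=O)N/N=C\c2ccc(C(F)(F)F)cc2)oc2cccc(O)c12` reaches only a limit of the assay, >= 40000 nM, so no number is available for it. Compound 2 `Cc1c(C(=O)N/N=C\c2ccco2)oc2cccc(O)c12` likewise reaches only a limit of the assay, >= 40000 nM, and stands there without a measured number. Two of the three values shown sit at this limit (the limit of >= 40000 nM in this assay, at which 2 of the 3 values shown sit), so compound 2 stands among the weakest results shown, with compound 3 beside it at the same limit.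

Compound 4 `Cc1c(C(=O)N/N=C\c2ccc(Br)cc2O)oc2cccc(O)c12` is not yet measured in this assay. It differs from compound 2 in one place (4-bromo-2-hydroxyphenyl in place of furan-2-yl on a carbon with a double bond to nitrogen). The furan-2-yl ring is replaced by a 4-bromo-2-hydroxyphenyl ring, which brings one hydrogen-bond donor where compound 2 had none on that ring. Within the data shown here, no step between measured compounds is available, so the size of the change cannot be read from the data; the expectation is a modest step in this assay toward stronger inhibition, close to the scatter, expressed as an at least 1.6-fold lower number from compound 2 to compound 4 (0.20 log units; that floor lies within the scatter). Compound 4 is therefore expected to give 25000 nM, in a range from 8000 nM to 40000 nM.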

Compound 4, half-maximal inhibitory concentration: 2050 nM
Compound 4: the middle estimate sits 12-fold (1.09 log units) above what was measured, and the stated range ends above it.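

The group on the carbon with a double bond to nitrogen turns out to matter a great deal in this assay: putting 4-bromo-2-hydroxyphenyl in place of furan-2-yl gives an at least 19-fold lower number from compound 2 to compound 4 (1.29 log units; beyond the scatter). Among the earlier compounds, only compound 1 had given a number, 26200 nM, so they could not show how far a change at this place might move the result, whereas compound 4 now gives a measured 2050 nM. The step is a lower bound rather than an exact size, since compound 2 has only a limit and its true value could lie further up: the limit of >= 40000 nM in this assay, at which 2 of the 4 values shown sit.

The compounds shown leave open which part of the new ring carries the gain, since the hydroxy group, the bromine and the change from a furan-2-yl ring to a carbon-only ring all arrive in one step, and no compound here separates them. They also leave open how the result would respond if the bromine gave way to another group on the same ring, such as an amine or a carboxylic acid.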